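The compounds below may be only part of what the source reports. "The series", "measured", "known", "first", "only" and "open" are said of these compounds alone.

Compound 1, `COc1ccc(Cl)c(N2CCC3(CCC(CC(=O)O)CC3)CC2)c1`: in a functional assay on HEK293 cells for agonist activity at Free fatty acid receptor 1 (Homo sapiens), read by HTRF and inositol phosphate accumulation, with a stated time of 60 min (a higher number here means that more compound is needed for the effect, a lower number that less compound is needed), compound 1 gives > 10000 nM, a limit of the assay rather than a number.
Compound 2, `O=C(O)CC1CCC2(CC1)CCN(c1cc(OC(F)(F)F)ccc1F)CC2`: in this assay compound 2 gives > 10000 nM, also a limit.
Compound 3, `O=C(O)CC1CCC2(CC1)CCN(c1cc(C(F)(F)F)ccc1F)CC2`: in this assay compound 3 gives > 10000 nM, again a limit.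

Compound 2 thus stands only as a limit, and every value shown sits there: the limit of > 10000 nM in this assay, at which 3 of the 3 values shown sit. For the measured compounds named here, the single measured step, a step that the two limits leave unreadable from compound 2 to compound 3, has limits at both ends and so carries no readable size. Compound 4, `N#Cc1ccc(OC(F)(F)F)cc1N1CCC2(CCC(CC(=O)O)CC2)CC1`, differs from compound 2 by cyano in place of fluoro on an aromatic carbon. Going by the values given here, no measured step bears on this change with a readable size, so the expectation can rest only on the three compounds sitting at the limit. The step from compound 2 to compound 4 is expected to be a step that the limit leaves unreadable from compound 2 to compound 4, not readable beyond the scatter. Compound 4 is estimated at 15000 nM, within 3000 nM to 60000 nM, with a fair chance that only a limit is reported again.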

Compound 4, half-maximal effective concentration: 2500 nM
Estimate against measurement, compound 4: 6.0-fold (0.78 log units) above, and the stated range ends above it.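

In this assay, cyano in place of fluoro on an aromatic carbon, ortho to a large group and para to a trifluoromethoxy group, gives an at least 4.0-fold lower number from compound 2 to compound 4 (0.60 log units; beyond the scatter). This is the only change shown that brings a compound off the limit, so what sits at this position matters for the read-out. The other step cannot be read, and the limit still holds most of the values: the limit of > 10000 nM in this assay, at which 3 of the 4 values shown sit.

From the compounds shown here alone, only compound 4 carries cyano, so whether it has the same effect alongside trifluoromethyl remains open. So does what an amine or a carboxamide would give at this carbon.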